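Pyridin-3-yl to pyridin-4-yl swap across two cores

A few compounds are considered here, and "the series" means these few. Any claim that something is new, unique, unknown or untested is made for them only; others in the source may bear on it.

Compound 1 `C[C@@H](NC(=O)[C@H](CCCNC(=N)N)NC(=O)c1ccc(CN(Cc2cccnc2)C(=O)c2ccc(F)cc2)cc1)c1cccc2ccccc12` and compound 2 `C[C@@H](NC(=O)[C@H](CCCNC(=N)N)NC(=O)c1ccc(CN(Cc2ccncc2)C(=O)c2ccc(F)cc2)cc1)c1cccc2ccccc12` share one core; compound 3 `C[C@H](NC(=O)[C@H](CCCNC(=N)N)NC(=O)c1ccc(CN(Cc2ccc(F)cc2)Cc2cccnc2)cc1)c1cccc2ccccc12` and compound 4 `C[C@H](NC(=O)[C@H](CCCNC(=N)N)NC(=O)c1ccc(CN(Cc2ccncc2)Cc2ccc(F)cc2)cc1)c1cccc2ccccc12` share another, and the difference between the two cores is not broken down here. In an assay on Jurkat cells for displacement of a labelled ligand from C-X-C chemokine receptor type 4 (Homo sapiens), tested at 10 uM (a higher number here means more inhibition at the concentration tested (going by the name of the read-out), a lower number less inhibition), compound 1 gives 11% and compound 2 gives 6%; the step of a number 5 percentage points lower from compound 1 to compound 2 (within the scatter) goes with the change (pyridin-4-yl in place of pyridin-3-yl on a saturated chain carbon bound to an amide-type nitrogen). In this assay compound 3 gives 27%, the highest of the three numbers, its gaps to compound 1 and to compound 2 both beyond the scatter. Compound 4 is not yet measured; it differs from compound 3 by pyridin-4-yl in place of pyridin-3-yl on a saturated chain carbon bound to an amine nitrogen. This is the same kind of change as that from compound 1 to compound 2, though the place is not the same: there the saturated chain carbon is bound to an amide-type nitrogen, here to an amine nitrogen. Because the earlier step of a number 5 percentage points lower from compound 1 to compound 2 (within the scatter) lay within the scatter, a similarly small step is expected here, a number 5 percentage points lower from compound 3 to compound 4 (within the scatter). Compound 4 is therefore estimated at 22%, with an expected range from 8% to 36%.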

Compound 4, a percentage reported as inhibition, at one concentration (the size of the read-out at that concentration, not a potency): 16%
Compound 4: middle estimate off by 6 percentage points, on the high side; low and high end bracket the measured number.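

On the core of compound 3, pyridin-4-yl in place of pyridin-3-yl on a saturated chain carbon bound to an amine nitrogen goes with a number 11 percentage points lower from compound 3 to compound 4 (beyond the scatter) in this assay. Set beside the same change on the core of compound 1, this step does not differ from the earlier one: the same change on two cores in this assay, a number 5 percentage points lower (within the scatter) from compound 1 to compound 2 and a number 11 percentage points lower (beyond the scatter) from compound 3 to compound 4, 6 percentage points apart, within the scatter of two such steps

So the two cores give no sign that the core alters the effect of this change, but with one pair per core, at a single concentration, this does not show that the step is the same size on both or that it would hold on a further core.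

Open, going by these compounds, is how a plain phenyl or a carboxylic acid in place of the pyridine ring, on the same saturated chain carbon, would read in this assay. Also open, on these data alone, is which part of the difference between the two cores goes with the gaps between their values.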